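The compounds below may be only part of what the source reports. "The series", "measured", "known", "first", "only" and "open" are said of these compounds alone.

Compound 1, `CC(=O)OC[C@H]1O[C@H](OC[C@@H](Cn2cc(CN(c3nc(-c4ccc(C)cc4)no3)C3CCCCC3)nn2)OC(C)=O)C=C[C@@H]1OC(C)=O`, has been measured in an ADME assay on HepG2 cells (Homo sapiens) for cytotoxicity, read by MTT assay, with a stated time of 48 h (on this read-out lower numbers stand for higher toxicity in this test and higher numbers for lower toxicity in this test), and in that test compound 1 gives 36.8 ug/mL. Within the data shown here, only one other compound has a number in this assay: compound 2, `C#CCN(c1nc(-c2ccc([N+](=O)[O-])cc2)no1)C1CCCCC1`, for which this assay gives 43.7 ug/mL. Compound 1 carries the lower of the two numbers, but the gap to compound 2 lies within the scatter, so the two results read as the same. Among the measured compounds shown here, no pair of measured compounds differing in a single place is available, so no measured step can be drawn on.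

Compound 3, `COc1ccc(-c2noc(N(Cc3cn(C[C@H](CO[C@@H]4C=C[C@H](OC(C)=O)[C@@H](COC(C)=O)O4)OC(C)=O)nn3)C3CCCCC3)n2)cc1`, is still to be measured in this assay. It differs from compound 1 in one place: methoxy in place of methyl on an aromatic carbon. Cut one bond further out, the change reads as 4-methylphenyl to 4-methoxyphenyl. Nothing in the measured pair points either way for such a change, so the step from compound 1 to compound 3 is expected to be none beyond the scatter, at a 1.0-fold higher number from compound 1 to compound 3 (0.01 log units; within the scatter). Compound 3 is thus estimated at 38 ug/mL, with a range from 19 ug/mL to 76 ug/mL.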

Compound 3, half-maximal cytotoxic concentration: 141 ug/mL
For compound 3 the middle estimate is 3.7-fold (0.57 log units) below the measured one; the whole stated range lies below it.
By their numbers in this assay, from the lowest: compounds 1 and 2 (each within the scatter of the next); then compound 3.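

In this assay, methoxy in place of methyl on an aromatic carbon, para to a large group, gives the first single-place step available for this series, with a 3.8-fold higher number from compound 1 to compound 3 (0.58 log units; beyond the scatter) as the change from 4-methylphenyl to 4-methoxyphenyl. The step runs toward lower toxicity in this test, so the number is not indifferent to what sits at this position, something the earlier pair could not show, as its two compounds do not differ in a single place. Nothing at hand accounts for the size or the direction of this step.

This single step leaves open whether the higher number goes with the oxygen of the methoxy group specifically, or whether a longer chain such as ethoxy, a hydroxyl, an amine or a chlorine at the same place would move the number the same way. It also leaves open whether the same exchange of methyl for methoxy would give a step of similar size on a different core.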